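Methyl to (trifluoromethyl)sulfanyl in a narrow set of values

The source may report more compounds than this note shows. Statements on the series, on what has been measured and on what is new or still open speak of the compounds shown alone.

In a functional assay on HeLa cells (Homo sapiens) for inhibition, read by MTT assay, with a stated time of 72 h (on this read-out higher numbers stand for weaker inhibition and lower numbers for stronger inhibition), compound 3 (`C=C(Br)C(=O)Nc1cccc(/C=C/C(=O)Nc2ccc(C)cc2)c1`) stands at 1500 nM and so lies within the scatter of compound 1 (`C=C(Br)C(=O)Nc1cccc(/C=C/C(=O)Nc2cccc(F)c2)c1`) at 1200 nM and of compound 2 (`C=C(Br)C(=O)Nc1cccc(/C=C/C(=O)Nc2ccc(F)c(F)c2)c1`) at 1900 nM as well. The next step leads to compound 4 (`C=C(Br)C(=O)Nc1cccc(/C=C/C(=O)Nc2ccc(SC(F)(F)F)cc2)c1`), with (trifluoromethyl)sulfanyl in place of methyl on an aromatic carbon, para to a large group ((trifluoromethyl)sulfanyl in place of methyl on an aromatic carbon). All three measured steps bear on this only indirectly, and all stay within the scatter: a 1.3-fold higher number from compound 1 to compound 3 (0.10 log units; within the scatter) and a 1.3-fold lower number from compound 2 to compound 3 (0.10 log units; within the scatter) for the exchanges that bring in 4-methylphenyl, and a 1.6-fold higher number from compound 1 to compound 2 (0.20 log units; within the scatter) for fluoro in place of hydrogen on an aromatic carbon. Among the compounds with values here, no measured compound carries the entering group, and these steps point in no clear direction. No change beyond the scatter is therefore expected, although the range is kept wide. In this assay the estimated step is a 1.1-fold lower number from compound 3 to compound 4 (0.03 log units; within the scatter) and stays within the scatter. Compound 4 is expected at 1400 nM with an estimated range from 650 nM to 3000 nM for now.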

Compound 4, half-maximal inhibitory concentration: 19000 nM
For compound 4 the middle estimate is 14-fold (1.13 log units) below the measured one; measured number above the stated range.
By their numbers in this assay, from the lowest: compounds 1, 3 and 2 (each within the scatter of the next); then compound 4.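

In this assay, the aromatic carbon para to a large group turns out to be sensitive to what it carries: a 13-fold higher number from compound 3 to compound 4 (1.10 log units; beyond the scatter). Within the data shown here, this is the first step to lie beyond the scatter, since the earlier exchanges among compound 1, compound 2 and compound 3 had all stayed within it, and it runs towards weaker inhibition. Nothing measured here explains why (trifluoromethyl)sulfanyl, with 5 heavy atoms against 1 for methyl, gives a step of this size.

The compounds shown do not separate the part played by the sulfur from that of the trifluoromethyl portion, so a plain trifluoromethyl or a methylsulfanyl group at this carbon could behave either way. Going by these compounds, how an amine or a carboxylic acid would behave at the same place also remains open.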